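A few compounds are considered here, and "the series" means these few. Any claim that something is new, unique, unknown or untested is made for them only; others in the source may bear on it.

Compound 1 `C=CC(C)(O)CC[C@@H]1C(=C)CC[C@H](Br)[C@@]1(C)CCC(O)C(C)(C)Cl`: > 100000 nM, a limit
Compound 2 `C=CC(C)(O)CC[C@@H]1C(=C)CC[C@H](Br)[C@@]1(C)CCC(O)C(C)(C)O`: > 100000 nM, a limit

In a functional assay on A-431 cells (Homo sapiens) for cytotoxicity, read by MTT assay, with a stated time of 48 h (on this read-out higher numbers stand for weaker inhibition and lower numbers for stronger inhibition), compound 2 stands only at a limit, > 100000 nM. Compound 3 `C=CC(C)(O)CC[C@@H]1C(=C)CC[C@H](Br)[C@@]1(C)CCC(OC)C(C)(C)O` has methyl in place of hydrogen on an oxygen on a saturated carbon, turning hydroxy to methoxy: methyl in place of hydrogen on an oxygen on a saturated carbon. Among the compounds with values here, the only measured step, a step that the two limits leave unreadable from compound 1 to compound 2, gives no size to build on, and the series offers just (the limit of > 100000 nM in this assay, at which 2 of the 2 values shown sit). No step beyond the scatter, in either direction, is therefore expected in this assay. The estimate amounts to a number no higher from compound 2 to compound 3 (the limit leaves the size open), an expected step read against a limit. The expected value for compound 3 is 100000 nM, with an estimated range of 50000 nM to 200000 nM.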

Compound 3, half-maximal inhibitory concentration: > 100000 nM
Compound 3: only a limit was reported; the forecaster's own chance of this, stated with the estimate: 85%; the middle value sits exactly at the limit.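

Within the data shown here, compound 3 also gives only a limit in this assay, > 100000 nM, so no step linking compound 1, compound 2 and compound 3 can be read. The compounds shown leave open whether hydroxy, chloro or methoxy changes cytotoxicity at all.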